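The compounds below may be only part of what the source reports. "The series", "measured", "known", "first", "only" and "open" are said of these compounds alone.

Two compounds of a shared core were examined in an assay on CHO cells for displacement of a labelled ligand from adenosine receptor A3 (Homo sapiens), read by scintillation counting, tested at 10 uM; a lower number here means less inhibition, a higher number more inhibition at the concentration tested (going by the name of the read-out). Compound 1, `CC(C)(C)Cc1c(/C=C/c2ccc(Cl)cc2)sc(N)c1C(=O)c1ccc(Cl)cc1`, carries a styryl-type side chain and in this assay compound 1 gives 11%. Compound 2, `COCCOc1ccc(-c2sc(N)c(C(=O)c3ccc(Cl)cc3)c2CC(C)(C)C)cc1`, carries instead an aryl ring bearing a 2-methoxyethoxy group; in this assay compound 2 gives 1%. The two numbers lie within the usual scatter of each other, so neither compound can be set apart from the other on this evidence.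

Compound 3, `Cc1ccc(-c2sc(N)c(C(=O)c3ccc(Cl)cc3)c2CC(C)(C)C)cc1`, is the next compound in this line. It differs from compound 2 in one place: methyl in place of 2-methoxyethoxy on an aromatic carbon. Nothing has yet been measured for this change, and the two numbers already in hand are both small, so compound 3 is expected to show a step of a number 5 percentage points higher from compound 2 to compound 3 (within the scatter) that does not go beyond the scatter. In this assay compound 3 is estimated at 6%, within a range from -8% to 22%.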

Compound 3, a percentage reported as inhibition, at one concentration (the size of the read-out at that concentration, not a potency): 1%
For compound 3 the middle estimate is 5 percentage points above the measured one, within the range that was stated.
By their numbers in this assay, from the lowest: compounds 2, 3 and 1 (each within the scatter of the next).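

In this assay, methyl in place of 2-methoxyethoxy on an aromatic carbon, para to a large group, gives no change at the digits printed from compound 2 to compound 3 (within the scatter), so removing the whole 2-methoxyethoxy chain with its oxygens leaves the reading where it stood. The larger exchange, 4-methylphenyl in place of 2-(4-chlorophenyl)ethenyl, gives a number 10 percentage points lower from compound 1 to compound 3 (within the scatter), so neither of the two single changes now in hand separates a pair of compounds beyond the scatter. Nothing at hand bears on why these readings fall as they do.

As far as these compounds go, it remains open whether any group on this aromatic carbon would move the reading beyond the scatter, for instance an amine, a carboxylic acid or a longer chain. The shared core outside this side chain is also untested by these compounds, since it stays the same throughout.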